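Trifluoromethyl for Nitro: Cytotoxicity Stays Beyond the Limit

The compounds below may be only part of what the source reports. "The series", "measured", "known", "first", "only" and "open" are said of these compounds alone.

In an ADME assay on HepG2 cells (Homo sapiens) for cytotoxicity, with a stated time of 48 h (a lower number here means a stronger inhibitor, a higher number a weaker inhibitor), compound 1 `O=[N+]([O-])c1cc(CSc2nnc(-c3ccc(Cl)cc3)n2Cc2ccccc2)cc([N+](=O)[O-])c1` gives > 30000 nM, which is a limit of the assay and not a number. In this assay compound 2 `O=[N+]([O-])c1cc(CSc2nnc(-c3ccc(Cl)cc3)n2Cc2ccccc2)cc(C(F)(F)F)c1` gives > 30000 nM, also a limit. In this assay compound 3 `COc1ccc(CSc2nnc(-c3cc([N+](=O)[O-])cc([N+](=O)[O-])c3)n2Cc2ccccc2)cc1` gives > 30000 nM, again a limit.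

The change from compound 1 to compound 2 is trifluoromethyl in place of nitro on an aromatic carbon. Its step, a step that the two limits leave unreadable from compound 1 to compound 2, cannot be sized. Compound 4 `COc1ccc(CSc2nnc(-c3cc([N+](=O)[O-])cc(C(F)(F)F)c3)n2Cc2ccccc2)cc1` carries the same change on the core of compound 3, namely (trifluoromethyl in place of nitro on an aromatic carbon); the two place descriptions match word for word. How the core of compound 3 differs from that of compound 1 is not broken down here.

Going by the values given here, the only evidence is the limit of > 30000 nM in this assay, at which 3 of the 3 values shown sit. Resting on it, the expected step that the limit leaves unreadable from compound 3 to compound 4 is expected to be small, and a limit is again expected rather than a number. Compound 4 is therefore estimated at 40000 nM, within 15000 nM to 120000 nM.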

Compound 4, half-maximal inhibitory concentration: > 30000 nM
Compound 4 was reported as a limit; the forecaster's own chance of this, stated with the estimate: 85%; the middle value does not contradict the limit.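

Compound 3 and compound 4 both give a limit in this assay and not a number, and the step between them cannot be read. The compounds shown leave open whether trifluoromethyl in place of nitro changes cytotoxicity at all.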